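Coumarin exchange and a tetrazole replacement in the amide series

A few compounds are considered here, and "the series" means these few. Any claim that something is new, unique, unknown or untested is made for them only; others in the source may bear on it.

Two compounds of this series have numbers in a functional assay on PC-3 cells (Homo sapiens) for antiproliferative activity, read by MTT assay, with a stated time of 48 h; a higher number here means a weaker inhibitor, a lower number a stronger inhibitor. Compound 1 `COc1ccc(CN(C(=O)Cn2cc(COc3cc(=O)oc4ccccc34)nn2)c2cc(OC)c(OC)c(OC)c2)cc1` gives 5140 nM in this assay. For the measured compounds named here, compound 2 `COc1ccc(CN(C(=O)Cn2cc(COc3ccc4ccc(=O)oc4c3)nn2)c2cc(OC)c(OC)c(OC)c2)cc1` gives 860 nM in this assay, the lowest of the two numbers, with compound 1 as its only neighbour; the step of a 6.0-fold lower number from compound 1 to compound 2 (0.78 log units; beyond the scatter) shows that exchanging one group for another of the same size, on an oxygen on a saturated carbon, already moves the number beyond the scatter. Compound 3 `COc1ccc(CN(C(=O)Cn2cc(CSc3nnnn3C)nn2)c2cc(OC)c(OC)c(OC)c2)cc1` is not yet measured. It differs from compound 2 as follows: a group of 7 heavy atoms (2 carbon, 4 nitrogen, 1 sulfur; one five-membered aromatic ring with 4 hetero atoms) in place of a group of 12 heavy atoms (9 carbon, 3 oxygen; one six-membered aromatic ring of carbon only, one six-membered aromatic ring with 1 hetero atom), on a saturated chain carbon bound to an aromatic carbon. Going by the values given here, no measured step covers a change of this kind; the one step available swaps like for like and offers no direct guide. Compound 3 is expected to show a step of a 7.0-fold higher number from compound 2 to compound 3 (0.84 log units; beyond the scatter), upward, as the larger group shared by the two measured compounds is removed. Compound 3 is therefore estimated at 6000 nM, within 1500 nM to 25000 nM.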

Compound 3, half-maximal inhibitory concentration: 10900 nM
Beside the measured number, compound 3's estimate is 1.8-fold (0.26 log units) below it; low and high end bracket the measured number.
By their numbers in this assay, from the lowest: compound 2; then compound 1; then compound 3.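

In this assay, for the compounds shown here, placing (1-methyl-1H-tetrazol-5-yl)sulfanyl on the saturated chain carbon bound to an aromatic carbon gives a 13-fold higher number from compound 2 to compound 3 (1.10 log units; beyond the scatter), the largest step so far. The same exchange gives only a 2.1-fold higher number from compound 1 to compound 3 (0.33 log units; beyond the scatter), so its size depends on which of the two larger groups leaves, and compound 3 has the highest number of the three, with both steps beyond the scatter. No measurement available here explains these steps.

The compounds shown do not separate the contribution of the sulfur link from that of the tetrazole ring, since both enter together. Also open, as far as these compounds go, is how a simple phenoxy group or a morpholine at this place would compare with the groups of compound 2 and compound 3.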